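Pyridinone nitrile series: aryl change on the piperidine ring

The source may hold more compounds than are shown below. What is called first, only, known or untested is meant among the compounds shown, and "the series" means these compounds.

Measured compounds:
- compound 1, `CC(C)CCn1ccc(N(C)Cc2ccccc2)c(C#N)c1=O`: 10700 nM
- compound 2, `N#Cc1c(N2CCC(c3ccccc3)CC2)ccn(CCC2CC2)c1=O`: 178 nM
- compound 3, `N#Cc1c(N2CCC(c3ccc(F)cc3)CC2)ccn(CC2CC2)c1=O`: 89 nM

All three were run in a functional assay on CHO cells for positive allosteric modulation of metabotropic glutamate receptor 2 (Homo sapiens), with a stated time of 30 min; a higher number here means that more compound is needed for the effect, a lower number that less compound is needed. Compound 1 gives 10700 nM and sits far above the other two. Compound 2 gives 178 nM and compound 3 gives 89 nM; these two lie within the usual scatter of each other, so no order between them can be read off. Compound 3 has the lowest number shown, with compound 2 close beside it and compound 1 well beyond the scatter above.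

Compound 4, `N#Cc1c(N2CCC(c3c(F)cccc3F)CC2)ccn(CC2CC2)c1=O`, is not yet measured. It differs from compound 3 in one place: 2,6-difluorophenyl in place of 4-fluorophenyl on a saturated ring carbon. For the measured compounds named here, no measured pair in this set shows a step of this kind, so its size and direction are not known from the data. The change keeps the aryl group and its size nearly unchanged, so a step no larger than the scatter is expected, with a slight lean toward a higher number; the estimated step is a 1.7-fold higher number from compound 3 to compound 4 (0.23 log units; within the scatter). For compound 4 the expected value in this assay is 150 nM, with a range from 40 nM to 600 nM.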

Compound 4, half-maximal effective concentration: 31 nM
For compound 4 the middle estimate is 4.8-fold (0.68 log units) above the measured one, outside the stated range (below it).
By their numbers in this assay, from the lowest: compound 4; then compounds 3 and 2 (each within the scatter of the next); then compound 1.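

In this assay, for the compounds shown here, 2,6-difluorophenyl in place of 4-fluorophenyl on a saturated ring carbon gives a 2.9-fold lower number from compound 3 to compound 4 (0.46 log units; beyond the scatter), the only single-place step so far. The position therefore responds to the fluorine substitution on the aryl group, even though the entering group differs only by a second fluorine and keeps the same aromatic ring of carbon. The step is modest but lies beyond the scatter, and nothing available explains its direction.

The compounds shown leave open whether 2-fluorophenyl, with its single fluorine, would give a similar step, and whether 2,6-dichlorophenyl or a pyridine ring would be accepted at this position. They also leave open whether 2,6-difluorophenyl gives a similar step when paired with the other chain on the ring nitrogen in compound 2.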